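A Small Amino Group in Place of Tert-Butyl

This account rests on a few compounds, and the source may have more. Where it says the series, first, only, none or still open, it means among the compounds named here.

Compound 1 `CC(C)(C)c1ccc(-n2c(-c3cccnc3N)nc3cccnc32)cc1` is tested in an in vitro assay on Sf9 cells for inhibition of RAC-alpha serine/threonine-protein kinase (Homo sapiens), read by AlphaScreen, with a stated time of 20 min (on this read-out lower numbers stand for stronger inhibition and higher numbers for weaker inhibition), where compound 1 gives 3900 nM. Among the three measured compounds this is the second highest number. Compound 2 `Nc1ncccc1-c1nc2cc(-c3cccnc3)cnc2n1-c1ccc(CNC(=O)c2ccccc2)cc1` carries a further six-membered ring on the shared core and a benzylamide arm on its phenyl ring; in this assay compound 2 gives 8 nM, far below compound 1. Compound 3 `Nc1ncccc1-c1nc2cccnc2n1-c1cccc(CNC(=O)c2ccccc2)c1` places the benzylamide arm at a different position of the phenyl ring and lacks the extra ring; in this assay compound 3 gives 13000 nM, above compound 1. Among the compounds with values here, no single-point step between measured compounds is available, so the size of the change now examined must be judged from the structural change alone.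

Compound 4 `Nc1ccc(-n2c(-c3cccnc3N)nc3cccnc32)cc1` differs from compound 1 in one place: amino in place of tert-butyl on an aromatic carbon. Because compound 1 already sits at 3900 nM and nothing measured shows how this change acts, a modest step toward a higher number, possibly within the scatter, is expected. For compound 4 the estimated value is 5000 nM, with a range from 1500 nM to 20000 nM, meaning an expected step of a 1.3-fold higher number from compound 1 to compound 4 (0.11 log units; within the scatter).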

Compound 4, half-maximal inhibitory concentration: 740 nM
Compound 4: the middle estimate sits 6.8-fold (0.83 log units) above what was measured; the whole stated range lies above it.
By their numbers in this assay, from the lowest: compound 2; then compound 4; then compound 1; then compound 3.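

In this assay, within the data shown here, amino in place of tert-butyl gives a 5.3-fold lower number from compound 1 to compound 4 (0.72 log units; beyond the scatter) and so shows that this aromatic carbon responds to a single change of group, which the earlier compounds, differing in more than one place, could not show. The tert-butyl, with its 4 heavy atoms, is therefore not required for the inhibition seen with compound 1, as the amino, with 1 heavy atom, gives a lower number. No measured evidence bears on why the number falls, so the step records an outcome and not an explanation.

Going by these compounds, whether the lower number comes from losing the tert-butyl or from gaining the amino stays open. A methyl or a hydroxyl group on the same carbon would help to separate these two possibilities.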